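Chloro for Methyl: Expecting the Value of Compound 4

The source may report more compounds than this note shows. Statements on the series, on what has been measured and on what is new or still open speak of the compounds shown alone.

Compound 1, `CC(=O)c1c(NNc2ccc(C)cc2)cc(C)oc1=O`: 70.2%
Compound 2, `CC(=O)c1c(NNc2ccc(Cl)cc2)cc(C)oc1=O`: 75.1%
Compound 3, `Cc1ccc(-n2nc3cc(C)oc(=O)c3c2C)cc1`: 69.4%

Of the compounds shown here, three have been tested in a functional assay on the whole organism (strain Swiss albino) with Mus musculus as the target, with stated times of 30 min and 10 min, at a dose of 50 mg/kg by the oral route; on this read-out lower numbers stand for less inhibition and higher numbers for more inhibition at the one dose given (going by the name of the read-out). Compound 1 and compound 2 share one core and differ in a single place: chloro in place of methyl on an aromatic carbon. That change produced a number 4.9 percentage points higher from compound 1 to compound 2 (within the scatter), so the two readings are not separable by this assay. Compound 3 is built on a different core; the difference between the core of compound 1 and the core of compound 3 is not broken down here. Its value in this assay sits close to that of compound 1 and of compound 2, all three within the scatter of one another, so no order among them can be claimed.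

Compound 4, `Cc1cc2nn(-c3ccc(Cl)cc3)c(C)c2c(=O)o1`, has not yet been measured. Going by the values given here, it differs from compound 3 by chloro in place of methyl on an aromatic carbon, the same change, at a place described in the same words, as the one between compound 1 and compound 2. Because that earlier change gave a number 4.9 percentage points higher from compound 1 to compound 2 (within the scatter), compound 4 is expected to show a step of similar size, a number 4.6 percentage points higher from compound 3 to compound 4 (within the scatter), in this assay. Compound 4 is therefore estimated at 74%, likely between 64% and 84%.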

Compound 4, a percentage reported as inhibition, in the whole organism at one dose (the size of the read-out at that dose, not a potency): 65.3%
Estimate against measurement, compound 4: 8.7 percentage points above; low and high end bracket the measured number.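

In this assay, chloro in place of methyl on the core of compound 3 gives a number 4.1 percentage points lower from compound 3 to compound 4 (within the scatter), so on this core the change cannot be told apart from the ordinary spread of repeated measurements. On paper the two steps point in opposite directions, yet the gap between them is also no larger than that spread: the same change on two cores in this assay, a number 4.9 percentage points higher (within the scatter) from compound 1 to compound 2 and a number 4.1 percentage points lower (within the scatter) from compound 3 to compound 4, 9 percentage points apart, within the scatter of two such steps. This gives no sign that the change behaves differently on the two cores, but it does not show that the change carries over from one to the other either, as neither step stands clear of the scatter and there is no firm effect to carry.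

The compounds shown leave open whether a different group at this place on the aromatic ring, such as an amine or a carboxylic acid, would give a step that stands clear of the scatter on either core. Also open, going by these compounds, is whether any such step would then be the same on both cores.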